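Extending the Aryl Ether Chain on a Thiazolidinedione Scaffold

The source may hold more compounds than are shown below. What is called first, only, known or untested is meant among the compounds shown, and "the series" means these compounds.

Compound 1 `O=C1N=C(O)S/C1=C\c1ccc(OCc2ccccc2)cc1Cl`: 487 nM
Compound 2 `O=C1N=C(O)S/C1=C\c1ccc(OCCc2ccccc2)cc1Cl`: 178 nM

Among the measured compounds shown here, compound 2 holds the lowest of the two numbers so far in an assay for inhibition of 15-hydroxyprostaglandin dehydrogenase [NAD(+)] (Homo sapiens), read by fluorescence and spectrophotometry; a lower number here means a stronger inhibitor, a higher number a weaker inhibitor; its nearest neighbour, compound 1, is the only other point, and the step of a 2.7-fold lower number from compound 1 to compound 2 (0.44 log units; beyond the scatter) lies beyond the scatter. The step to compound 3 `O=C1N=C(O)S/C1=C\c1ccc(OCCCc2ccccc2)cc1Cl` is benzyl in place of phenyl on a saturated chain carbon, two bonds along the chain from an oxygen on an aromatic ring. This is the same kind of change, the tether between the ether oxygen and the distal phenyl ring growing by one carbon, now applied one bond further along the chain. One earlier step bears on it: a 2.7-fold lower number from compound 1 to compound 2 (0.44 log units; beyond the scatter) was a modest gain for the first lengthening. Whether a second lengthening continues that trend cannot be read from two points, so a smaller gain, or none beyond the scatter, is the most defensible expectation. Compound 3 is therefore estimated at 120 nM in this assay, with a range from 50 nM to 350 nM, meaning an expected step of a 1.5-fold lower number from compound 2 to compound 3 (0.17 log units; within the scatter).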

Compound 3, half-maximal inhibitory concentration: 52 nM
Beside the measured number, compound 3's estimate is 2.3-fold (0.36 log units) above it, and the stated range covers the measured number.
By their numbers in this assay, from the lowest: compound 3; then compound 2; then compound 1.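

The second lengthening did not fade: the same change, benzyl in place of phenyl, applied one bond further along the chain, gives a 3.4-fold lower number from compound 2 to compound 3 (0.53 log units; beyond the scatter) in this assay, so the gain seen at the first lengthening carries on and does not level off at compound 2. Read as a single change, phenethyl in place of phenyl on the saturated chain carbon bound to the oxygen on the aromatic ring gives a 9.4-fold lower number from compound 1 to compound 3 (0.97 log units; beyond the scatter), and both single steps along the way lie beyond the scatter, so the number falls at each stage of this short series and none of the three compounds goes against that. Nothing available explains why this chain length is favoured.

Three compounds cannot show where this trend ends, and a longer chain than that of compound 3 could continue the fall, level off or reverse it. From the compounds shown here alone, it also remains open whether the terminal phenyl is needed at all, or whether an amine or a carboxylic acid in its place on the chain would keep the gain.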